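A few compounds are considered here, and "the series" means these few. Any claim that something is new, unique, unknown or untested is made for them only; others in the source may bear on it.

Values measured in a functional assay on A549 cells (Homo sapiens) for antiproliferative activity, read by MTT assay, with a stated time of 48 h; a higher number here means a weaker inhibitor, a lower number a stronger inhibitor:
- compound 1 `CN(C)CCCn1c(N)c(-c2nc3ccccc3n2C)c2nc(C#N)c(C#N)nc21`: 11700 nM
- compound 2 `CN(C)CCCCn1c(N)c(-c2nc3ccccc3n2C)c2nc(C#N)c(C#N)nc21`: 6150 nM
- compound 3 `CCN(CC)CCCCn1c(N)c(-c2nc3ccccc3n2C)c2nc(C#N)c(C#N)nc21`: 1720 nM

Compound 2, at 6150 nM, has no clear gap on one side, with a 1.9-fold lower number from compound 1 to compound 2 (0.28 log units; within the scatter), but a clear gap on the other, with a 3.6-fold lower number from compound 2 to compound 3 (0.55 log units; beyond the scatter).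

Compound 4 `CN(C)CCCCn1c(N)c(-c2nc3cc(Cl)ccc3[nH]2)c2nc(C#N)c(C#N)nc21` keeps the 4-(dimethylamino)butyl group of compound 2 and alters the group on the aromatic carbon next to the ring atom that bears an amino group: 5-chloro-1H-benzimidazol-2-yl in place of 1-methyl-1H-benzimidazol-2-yl on an aromatic carbon. The swap adds a chlorine and a hydrogen-bond donor, and the methyl on the ring nitrogen is gone.

All three measured compounds carry 1-methyl-1H-benzimidazol-2-yl, so every measured step concerns the amine chain and none tests this swap. The largest, a 6.8-fold lower number from compound 1 to compound 3 (0.83 log units; beyond the scatter), only shows how far a single change has moved the number in this small set. A step of similar or smaller size is therefore expected in this assay, leaning towards a lower number, though no measurement supports that direction. The expected step is a 2.2-fold lower number from compound 2 to compound 4 (0.34 log units; beyond the scatter). Compound 4 is estimated at 2800 nM, with an expected range of 600 nM to 10000 nM.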

Compound 4, half-maximal inhibitory concentration: 12100 nM
Compound 4: the middle estimate sits 4.3-fold (0.64 log units) below what was measured; the measured number lies above the stated range.
By their numbers in this assay, from the lowest: compound 3; then compounds 2, 1 and 4 (each within the scatter of the next).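

Among these compounds, this is the first change at the aromatic carbon next to the ring atom that bears an amino group, and in this assay it gives a 2.0-fold higher number from compound 2 to compound 4 (0.29 log units; within the scatter). Swapping 1-methyl-1H-benzimidazol-2-yl for 5-chloro-1H-benzimidazol-2-yl adds a chlorine and a hydrogen-bond donor and removes the methyl, yet the number stays within the scatter, whereas the change on the amine gave a 3.6-fold lower number from compound 2 to compound 3 (0.55 log units; beyond the scatter). No measurement at hand bears on the reason for this result.

The chlorine and the loss of the methyl arrive together, so their separate contributions cannot be told apart; the plain 1H-benzimidazol-2-yl group and the 5-chloro-1-methyl-1H-benzimidazol-2-yl group would separate them. As far as these compounds go, whether a fluorine or a methoxy group in the chlorine's place would behave alike also stays open.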